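This account rests on a few compounds, and the source may have more. Where it says the series, first, only, none or still open, it means among the compounds named here.

Compound 1 `CCOC(=O)CSc1nnc(C)n1N1C(=O)c2ccccc2C1=O` carries an ethoxycarbonyl group on a saturated chain carbon bound to a sulfur. In a functional assay on PC-3M cells (Homo sapiens) for cytotoxicity, read by MTT assay, with a stated time of 48 h (a higher number here means a weaker inhibitor, a lower number a stronger inhibitor), compound 1 gives only a limit, > 200000 nM. Compound 2 `C#CCSc1nnc(C)n1N1C(=O)c2ccccc2C1=O` has ethynyl in that place, and in this assay compound 2 likewise gives only a limit, > 200000 nM. Compound 3 `C#CCSc1nnc(CC)n1N1C(=O)c2ccccc2C1=O` adds a methyl on a saturated chain carbon bound to an aromatic carbon; in this assay compound 3 again gives only a limit, > 200000 nM. Compound 3 thus stands at the limit shared by all three values (the limit of > 200000 nM in this assay, at which 3 of the 3 values shown sit). The measured steps, a step that the two limits leave unreadable from compound 1 to compound 2 and a step that the two limits leave unreadable from compound 2 to compound 3, cannot be sized. Compound 4 `C=CCSc1nnc(CC)n1N1C(=O)c2ccccc2C1=O` differs from compound 3 by vinyl in place of ethynyl on a saturated chain carbon bound to a sulfur. Because the neighbouring values are all limits (the limit of > 200000 nM in this assay, at which 3 of the 3 values shown sit), compound 4 is expected to give 300000 nM, estimated between 150000 nM and 2000000 nM. The expected step is a step that the limit leaves unreadable from compound 3 to compound 4, no change beyond the scatter.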

Compound 4, half-maximal inhibitory concentration: > 200000 nM
Compound 4 was reported as a limit; the forecaster's own chance of this, stated with the estimate: 85%; the middle value lies beyond the limit too.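

The step from compound 3 to compound 4 cannot be sized, since both values are limits and not numbers: the limit of > 200000 nM in this assay, at which 4 of the 4 values shown sit. The compounds shown leave open how strongly any of them acts on these cells, and whether any of these group changes alters that.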